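The compounds below may be only part of what the source reports. "The series", "measured", "known", "first", "only" and "open" are said of these compounds alone.

Compound 1 `O=C(Nc1cccc(F)c1)c1cc(=O)[nH]c2cc(Br)ccc12` is the reference point of this small series. In a functional assay on KYSE-410 cells (Homo sapiens) for antiproliferative activity, read by MTT assay, with a stated time of 72 h (a higher number here means a weaker inhibitor, a lower number a stronger inhibitor), compound 1 gives 7300 nM, the lowest of the three numbers recorded, though none of its neighbours sits beyond the scatter from it. Compound 2 `O=C(Nc1cc(F)cc(F)c1)c1cc(=O)[nH]c2cc(Br)ccc12` gives 11200 nM in this assay, and compound 3 `O=C(Nc1cccc(OC(F)(F)F)c1)c1cc(=O)[nH]c2cc(Br)ccc12` gives 14000 nM. The two measured steps both alter the anilide ring: a 1.5-fold higher number from compound 1 to compound 2 (0.19 log units; within the scatter) and a 1.9-fold higher number from compound 1 to compound 3 (0.28 log units; within the scatter), each within the scatter.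

Compound 4 `Nc1ccc(-c2ccc3c(C(=O)Nc4cccc(F)c4)cc(=O)[nH]c3c2)cc1` changes a different part of the molecule: 4-aminophenyl in place of bromo on an aromatic carbon. Neither measured step touches this position, so nothing recorded bears directly on the change; the steps from compound 1 to compound 2 and from compound 1 to compound 3 only show that variation at the anilide ring left this assay unmoved within the scatter. Whether a 4-aminophenyl in place of bromo on the core moves the number is therefore open. Compound 4 is expected to land at 4000 nM, within a wide range of 800 nM to 20000 nM. This estimate means a step of a 1.8-fold lower number from compound 1 to compound 4 (0.26 log units; within the scatter), which is expected to be modest and uncertain in direction given the absence of any comparable measured step.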

Compound 4, half-maximal inhibitory concentration: > 20000 nM
Compound 4: only a limit was reported; the forecaster's own chance of this, stated with the estimate: 10%; middle value at least 5.0-fold (0.69 log units) away from the limit.
By their numbers in this assay, from the lowest: compounds 1, 2 and 3 (each within the scatter of the next). At a limit, above all of these: compound 4.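

In this assay, 4-aminophenyl in place of bromo on the core gives an at least 2.7-fold higher number from compound 1 to compound 4 (0.43 log units; beyond the scatter), the only step shown that lies beyond the scatter, whereas both changes on the anilide ring stay within it. This position on the core, unlike the anilide ring, therefore responds to substitution in this assay, and it does so in the direction of a weaker inhibitor, with a single larger aromatic group replacing a single halogen. The entry for compound 4 is a limit and not a number, so the step fixes a direction and a minimum, but not a full size: the limit of > 20000 nM in this assay, at which 1 of the 4 values shown sits.

The compounds shown leave open whether the step follows the added ring or the amine on it, a question that an unsubstituted phenyl, a 4-hydroxyphenyl or a 4-methoxyphenyl at the same position would help to settle. From the compounds shown here alone, it also remains open whether a smaller group such as chloro or methyl would keep the number of compound 1, and whether 4-aminophenyl has the same effect on the anilide ring of compound 2 or compound 3.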